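Working notes on compound 4: antiproliferative read-out

A few compounds are considered here, and "the series" means these few. Any claim that something is new, unique, unknown or untested is made for them only; others in the source may bear on it.

Measured compounds:
Compound 1 `N#CC1=C(N)Oc2c(c3nc4ccccc4nc3c3ccccc23)C12C(=O)N(Cc1cnnn1-c1ccc(Cl)cc1)c1ccccc12`: in an ADME assay on L02 cells (Homo sapiens) for antiproliferative activity, read by MTT assay, with a stated time of 48 h (on this read-out higher numbers stand for weaker inhibition and lower numbers for stronger inhibition), compound 1 gives > 50000 nM, which is a limit of the assay and not a number.
Compound 2 `CC(=O)Nc1ccc(-n2nncc2CN2C(=O)C3(C(C#N)=C(N)Oc4c3c3nc5ccccc5nc3c3ccccc43)c3ccccc32)cc1`: in this assay compound 2 gives > 50000 nM, again a limit.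
Compound 3 `N#CC1=C(N)Oc2c(N)cc3nc4ccccc4nc3c2C12C(=O)N(Cc1cnnn1-c1ccc(Cl)cc1)c1ccccc12`: in this assay compound 3 gives > 50000 nM, also a limit.

Compound 3 therefore stands at the limit of the assay, as do the other two values shown (the limit of > 50000 nM in this assay, at which 3 of the 3 values shown sit); no order among the three can be read from these numbers.

Compound 4 `COc1ccccc1-n1nncc1CN1C(=O)C2(C(C#N)=C(N)Oc3c(N)cc4nc5ccccc5nc4c32)c2ccccc21` differs from compound 3 by 2-methoxyphenyl in place of 4-chlorophenyl on an aromatic nitrogen. Within the data shown here, the only measured single change in the set, a step that the two limits leave unreadable from compound 1 to compound 2, runs between two limits, so its size is unreadable and gives no guide to the direction of the present change. Among the measured compounds shown here, no measured step bears readably on the new substitution.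

With every value at the limit, no step beyond the scatter is expected from compound 3 to compound 4, a step that the limit leaves unreadable from compound 3 to compound 4. Compound 4 is estimated to give 60000 nM in this assay, within 30000 nM to 200000 nM, and is expected most likely to be reported only as a limit.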

Compound 4, half-maximal inhibitory concentration: > 50000 nM
Compound 4: a limit, no number; the forecaster's own chance of this, stated with the estimate: 85%; the middle value is on the limit's open side.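

In this assay no new step can be read: compound 3 and compound 4 both give a limit and not a number, and the size of the change from 4-chlorophenyl to 2-methoxyphenyl stays unreadable. The compounds shown leave open how any of them ranks against another: the limit of > 50000 nM in this assay, at which 4 of the 4 values shown sit.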